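The compounds below may be only part of what the source reports. "The series", "measured", "known", "first", "only" and "open" are said of these compounds alone.

Values measured so far in a functional assay on DLD-1 cells (Homo sapiens) for cytotoxicity, with a stated time of 48 h; on this read-out lower numbers stand for stronger inhibition and higher numbers for weaker inhibition

compound 1 `CCCC(=O)Oc1ccc2oc(/C=C/[S+](C)[O-])cc(=O)c2c1` gives 8700 nM
compound 2 `CC(C)CC(=O)Oc1ccc2oc(/C=C/[S+](C)[O-])cc(=O)c2c1` gives 6100 nM
compound 3 `C[S+]([O-])/C=C/c1cc(=O)c2cc(Cl)ccc2o1` gives 6500 nM

Compound 3 stands at 6500 nM and is not clearly separated from the other two, with a 1.1-fold higher number from compound 2 to compound 3 (0.03 log units; within the scatter) and a 1.3-fold lower number from compound 1 to compound 3 (0.13 log units; within the scatter) on this scale. The next compound to be tested, compound 4 `CCCOc1ccc2oc(/C=C/[S+](C)[O-])cc(=O)c2c1`, has not yet been measured. It carries propoxy in place of chloro on an aromatic carbon and otherwise matches compound 3.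

The most relevant evidence comes from changes at that same aromatic carbon. Exchanging the group there for chloro gave only small shifts in the two steps above, even though both groups removed were larger than chloro. Altering the chain of such a group also did little, with a 1.4-fold lower number from compound 1 to compound 2 (0.15 log units; within the scatter) in this assay as the result. For the measured compounds named here, no compound with propoxy has been measured, so this evidence is indirect and the range must stay wide.

On this basis, no shift beyond the scatter is expected. The estimated change is a 1.1-fold higher number from compound 3 to compound 4 (0.03 log units; within the scatter) in this comparison. For compound 4 the estimated value is 7000 nM, with an expected range from 2800 nM to 18000 nM as its limits.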

Compound 4, half-maximal inhibitory concentration: 6200 nM
Compound 4: the middle estimate sits 1.1-fold (0.05 log units) above what was measured; the measured number falls inside the stated range.
By their numbers in this assay, from the lowest: compounds 2, 4, 3 and 1 (each within the scatter of the next).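

In this assay, this aromatic carbon tolerates a change from a single chlorine to propoxy, a chain of four heavy atoms that adds a hydrogen-bond acceptor, with the result being a 1.0-fold lower number from compound 3 to compound 4 (0.02 log units; within the scatter) on this scale. The earlier compounds shown here placed only chloro or a carbonyl-bearing group on this carbon, whereas compound 4 keeps the oxygen on the ring and drops the carbonyl, so that propyl in place of propylcarbonyl gives a 1.4-fold lower number from compound 1 to compound 4 (0.15 log units; within the scatter) and propyl in place of isobutylcarbonyl gives a 1.0-fold higher number from compound 2 to compound 4 (0.01 log units; within the scatter) in the same assay. Nothing measured here accounts for how little the number moves across these groups.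

All four compounds remain within the scatter of one another, so the compounds shown do not identify any group at this aromatic carbon that separates clearly from the rest. From the compounds shown here alone, whether an amine, a carboxylic acid or a much longer chain at this carbon would move the number beyond the scatter remains open, as does the effect of changes elsewhere on the shared core.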